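The compounds below may be only part of what the source reports. "The series", "measured", "known", "first", "only" and "open" are said of these compounds alone.

Among the measured compounds shown here, in a functional assay on the whole organism for antagonist activity, with Mus musculus as the target (a higher number here means that more compound is needed for the effect, a lower number that less compound is needed), compound 2 `CC(C)NCC(=O)NCC(=O)N(C)c1ccc(Cl)cc1C(=O)c1ccccc1Cl` gives 1 mg/kg, the lower of the two numbers measured so far. Compound 1 `CC(=O)NCC(=O)Nc1ccc(Cl)cc1C(=O)c1ccccc1` gives 37 mg/kg, a gap beyond the scatter. Compound 3 `CN(C(=O)CNC(=O)c1ccccc1)c1ccc(Cl)cc1C(=O)c1ccccc1Cl` arises from compound 2 by phenyl in place of (isopropylamino)methyl on a carbonyl carbon, with phenyl in place of (isopropylamino)methyl on a carbonyl carbon. For the measured compounds named here, no measured step covers this change, and the only guide is compound 1 at 37 mg/kg. A higher number beyond the scatter is expected, a 12-fold higher number from compound 2 to compound 3 (1.08 log units; beyond the scatter). For compound 3 the estimated dose is 12 mg/kg, with an expected range of 3 mg/kg to 50 mg/kg.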

Compound 3, dose for half-maximal effect: 2.9 mg/kg
Estimate against measurement, compound 3: 4.1-fold (0.62 log units) above; the whole stated range lies above it.
By their numbers in this assay, from the lowest: compound 2; then compound 3; then compound 1.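

In this assay phenyl in place of (isopropylamino)methyl on a carbonyl carbon gives a 2.9-fold higher number from compound 2 to compound 3 (0.46 log units; beyond the scatter) and so only a modest rise. At this position, the (isopropylamino)methyl group is therefore not required for a dose in the low range, although the change is beyond the scatter. No available measurement accounts for this step.

The compounds shown do not separate the loss of the isopropylamino group from the gain of the aromatic ring. A cyclohexyl or benzylaminomethyl group on this carbonyl carbon would bear on that question.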